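The source may hold more compounds than are shown below. What is called first, only, known or untested is meant among the compounds shown, and "the series" means these compounds.

Of the compounds shown here, two have been measured in an assay on membranes from HeLa cells for displacement of a labelled ligand from adenosine receptor A3 (Homo sapiens), read by scintillation counting, with a stated time of 180 min, tested at 1 uM; on this read-out lower numbers stand for less inhibition and higher numbers for more inhibition at the one concentration tested (going by the name of the read-out). Compound 1 `CC1=C(C(=O)C2CC2)C(c2ccsc2)NC(=O)N1` carries a cyclopropyl ketone and a thiophen-3-yl group on its core; in this assay compound 1 gives 1%. Compound 2 `CCC(C)OC(=O)C1=C(C)NC(=O)NC1c1cccs1` carries a sec-butyl ester and a thiophen-2-yl group; in this assay compound 2 gives 7%. Among the numbers shown, the one for compound 2 and the one for compound 1 lie within the scatter of each other, so neither compound stands apart from the other on this read-out.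

Compound 3 `CCC(C)OC(=O)C1=C(C)NC(=O)NC1c1ccsc1` has the same atoms as compound 2, joined differently: thiophen-3-yl in place of thiophen-2-yl on a saturated ring carbon. The sec-butyl ester, the methyl group and the rest of the core are kept. Among the compounds with values here, no step between measured compounds is available to show what such a change does, and the two measured values give no hint of a change beyond the scatter. The step of a number 1 percentage points lower from compound 2 to compound 3 (within the scatter) is therefore expected to be small, with no clear direction. Compound 3 is estimated to give 6%, with a range from 0% to 20%.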

Compound 3, a percentage reported as inhibition, at one concentration (the size of the read-out at that concentration, not a potency): 7%
Estimate against measurement, compound 3: 1 percentage points below; low and high end bracket the measured number.
By their numbers in this assay, from the lowest: compounds 1, 2 and 3 (each within the scatter of the next).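

Within the data shown here, the swap of thiophen-3-yl for thiophen-2-yl on the saturated ring carbon gives no change at the digits printed from compound 2 to compound 3 (within the scatter) in this assay, the first direct look at this position, and the point of attachment of the thiophene makes no visible difference to this read-out. With thiophen-3-yl held constant, sec-butoxy in place of cyclopropyl on the carbonyl carbon gives a number 6 percentage points higher from compound 1 to compound 3 (within the scatter), so turning the ketone of compound 1 into the ester of compound 3 also leaves the result within the usual spread, and neither of the two places has yet produced a step that stands out. No independent measurement is available that could explain these results.

The compounds shown leave open whether anything at the saturated ring carbon other than a thiophene, such as a phenyl ring or a pyridine, would give a step beyond the scatter. They also leave open what an amine or a carboxylic acid, or a longer chain such as n-hexyloxy in place of sec-butoxy on the carbonyl carbon, would do in this assay.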